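The compounds below may be only part of what the source reports. "The series", "measured", "known", "first", "only" and "open" are said of these compounds alone.

Three related compounds have been tested in a functional assay on RKO cells (Homo sapiens) for inhibition, read by MTT assay, with a stated time of 48 h; on this read-out lower numbers stand for stronger inhibition and higher numbers for weaker inhibition. Compound 2 (`COc1ccc(N(C)c2nc(C)nc3ccccc23)cc1[Se]C`) gives 11 nM and compound 1 (`Cc1nc(N(C)c2ccc([Se]C#N)c(C)c2)c2ccccc2n1`) gives 17 nM, and these two values lie within the usual scatter of each other. Compound 3 (`Cc1nc(N(C)c2ccc(OCC[Se]C#N)cc2)c2ccccc2n1`) gives 652 nM, a number far higher than either and well beyond the scatter. Compound 2 therefore stands level with compound 1, at the strong end of this small set.

The next structure is compound 4 (`COc1ccc(N(C)c2nc(C)nc3ccccc23)cc1[Se]C#N`), which has not yet been measured. It differs from compound 2 by one small edit, cyano in place of methyl on a selenium.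

Within the data shown here, no measured pair shows this exact change, so the expectation rests on indirect evidence. On a selenium whose other neighbour is an aromatic carbon, cyano is also found in compound 1, which gives 17 nM. Compound 3 also carries cyano on a selenium, but there the selenium is not bound to an aromatic carbon, and it gives 652 nM. Cyano on a selenium therefore does not ensure a low number by itself, although compound 4 matches compound 1 in this respect.

No step beyond the scatter is expected, and the estimated change is a 1.1-fold higher number from compound 2 to compound 4 (0.04 log units; within the scatter). For compound 4 the expected value in this assay is 12 nM, with an estimated range from 4 nM to 40 nM.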

Compound 4, half-maximal inhibitory concentration: 47 nM
For compound 4 the middle estimate is 3.9-fold (0.59 log units) below the measured one, and the stated range ends below it.
By their numbers in this assay, from the lowest: compounds 2 and 1 (each within the scatter of the next); then compound 4; then compound 3.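

In this assay, putting cyano in place of methyl on a selenium whose other neighbour is an aromatic carbon gives a 4.3-fold higher number from compound 2 to compound 4 (0.63 log units; beyond the scatter). Among these compounds, this is the first direct reading of the change: no two of the earlier compounds differed in only one place, so the effect of cyano on selenium could not be separated from the other differences between them. On the shared core of this pair, methyl on the selenium goes with the lower number, and although the step is modest, it lies beyond the usual scatter. Nothing available here explains why the swap has this effect.

This single pair cannot show whether the same swap would give a step of similar size or direction on another core, such as that of compound 1. It also leaves open how the number would respond if the selenium carried a different group, such as an ethyl group, a longer carbon chain or a benzyl group, and so whether methyl is the best choice at this position or only better than cyano.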